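The source may report more compounds than this note shows. Statements on the series, on what has been measured and on what is new or still open speak of the compounds shown alone.

For the measured compounds named here, compound 2 `O=S(=O)(/C=C/c1ncccc1Cl)c1ccccc1Cl` holds the lower of the two numbers measured so far: in an assay on U2OS cells for activation of nuclear factor erythroid 2-related factor 2 (Homo sapiens), read by beta-arrestin recruitment, with a stated time of 6 h (a higher number here means that more compound is needed for the effect, a lower number that less compound is needed), compound 2 gives 26 nM, whereas compound 1 `O=S(=O)(/C=C\c1ncccc1F)c1ccccc1Cl` gives 583 nM in this assay, a gap well beyond the scatter. Compound 3 `O=S(=O)(/C=C\c1ncccc1Cl)c1ccccc1Cl` is compared with compound 2 next; the change is the two compounds have the same atoms and bonds and differ only in configuration as drawn: 1 of 1 stereo elements differ; a double bond is drawn E in compound 2 and Z in compound 3. Going by the values given here, with no measured pair differing in this way, the step is uncertain, but a rise is expected, since compound 1, also drawn Z, gives 583 nM. The step is expected to be a 5.8-fold higher number from compound 2 to compound 3 (0.76 log units; beyond the scatter). Compound 3 is estimated at 150 nM, within 25 nM to 900 nM.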

Compound 3, half-maximal effective concentration: 1100 nM
Compound 3: the middle estimate sits 7.3-fold (0.87 log units) below what was measured, outside the stated range (above it).
By their numbers in this assay, from the lowest: compound 2; then compounds 1 and 3 (each within the scatter of the next).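

For the compounds shown here, this is the first pair to isolate the double bond, and the whole change in this assay, a 42-fold higher number from compound 2 to compound 3 (1.63 log units; beyond the scatter), can be traced to its configuration on this ground: the fact that compounds 2 and 3 differ only in the configuration as drawn. With the double bond drawn Z, chloro in place of fluoro on an aromatic carbon gives a 1.9-fold higher number from compound 1 to compound 3 (0.28 log units; within the scatter), so the two halogens cannot be told apart in that setting.

As far as these compounds go, whether the E double bond gives a similar gain with fluoro in place of chloro remains open. So does the effect of a nitrile or a methoxy group at that aromatic carbon.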